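The source may hold more compounds than are shown below. What is called first, only, known or untested is meant among the compounds shown, and "the series" means these compounds.

Measured so far:
- compound 1 `Cc1nc2c(cnn2-c2ccccc2)c(=O)n1N1CCCCCC1`: in an in vitro functional assay on cells for antagonist activity at metabotropic glutamate receptor 5 (Homo sapiens), read by FLIPR and calcium flux (on this read-out higher numbers stand for weaker inhibition and lower numbers for stronger inhibition), compound 1 gives 3600 nM
- compound 2 `Cc1nc2c(cnn2CC2CCCCC2)c(=O)n1-c1ccc(Cl)cc1`: compound 2 is reported only as a limit, > 100000 nM
- compound 3 `Cc1ccccc1-n1ncc2c(=O)n(-c3ccc(Cl)cc3)c(C)nc21`: in this assay compound 3 gives 9500 nM

Compound 3 holds the highest of the two numbers shown; compound 1 sits lower, and the remaining entry is a limit of > 100000 nM in this assay, at which 1 of the 3 values shown sits, rather than a number.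

The next compound, compound 4 `Cc1cccc(-n2ncc3c(=O)n(-c4ccc(Cl)cc4)c(C)nc32)c1`, differs from compound 3 by 3-methylphenyl in place of 2-methylphenyl on an aromatic nitrogen. Going by the values given here, the only measured step at that same aromatic nitrogen is an at least 10-fold lower number from compound 2 to compound 3 (1.02 log units; beyond the scatter), a large move, but it exchanges an entirely different group for the 2-methylphenyl and says nothing about where a methyl sits on that ring. Among the compounds with values here, no pair among the measured compounds separates a 2-methylphenyl from a 3-methylphenyl, so there is no direct guide. With the same atoms joined differently and only the ring position of the methyl moved, the working expectation in this assay is a step near or within the scatter, with a slight lean toward a lower number; the expected step is a 1.6-fold lower number from compound 3 to compound 4 (0.20 log units; within the scatter). Compound 4 is accordingly estimated at 6000 nM, expected to fall between 1500 nM and 25000 nM.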

Compound 4, half-maximal inhibitory concentration: > 100000 nM
Compound 4: only a limit was reported (the forecaster's own chance of this, stated with the estimate: 10%); at least 16-fold (1.22 log units) between middle value and limit.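

At the aromatic nitrogen, moving only the methyl, from 2-methylphenyl to 3-methylphenyl, gives an at least 10-fold higher number from compound 3 to compound 4 (1.02 log units; beyond the scatter) in this assay, so this position responds to where the methyl sits on the ring, not only to which kind of group is attached. The entry for compound 4, > 100000 nM, is a limit of the assay. Among the three compounds that share the 4-chlorophenyl group, only compound 3 gives a number, and the step between the other two cannot be read, since both of its ends are limits: the limit of > 100000 nM in this assay, at which 2 of the 4 values shown sit.

Open, from the compounds shown here alone, is whether the 2-methylphenyl result depends on the methyl itself or would also hold for a 2-chlorophenyl or 2-methoxyphenyl at this nitrogen, and compound 1, with its plain phenyl there, differs in a second place and cannot settle this. Also open, going by these compounds, is whether the same sensitivity to the methyl position holds when the 4-chlorophenyl group on the core gives way to another group, such as a morpholine.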